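Chloro for methoxy on the pendant aryl of compound 1

The source may hold more compounds than are shown below. What is called first, only, known or untested is meant among the compounds shown, and "the series" means these compounds.

Compound 1 `COc1ccc(N2C(=O)COc3ccc(-c4cnc(OC)c(NS(=O)(=O)c5ccc(F)cc5)c4)cc32)cc1` carries a methoxy on the pendant aryl. Among the measured compounds shown here, in a functional assay on MCF7 cells (Homo sapiens) for antiproliferative activity, read by MTT assay, with a stated time of 72 h (a lower number here means a stronger inhibitor, a higher number a weaker inhibitor), compound 1 gives 8260 nM, the only numeric reading. Compound 2 `O=C1COc2ccc(-c3cnc4ccccc4c3)cc2N1` returns only a limit, > 40000 nM. Compound 3 `COc1ncc(-c2ccc3c(c2)N(c2ccc(Cl)cc2)C(=O)CO3)cc1NS(=O)(=O)c1ccc(F)cc1` differs from compound 1 by chloro in place of methoxy on an aromatic carbon. For the measured compounds named here, no measured pair isolates this exchange, so the expected step in this assay is small, within the scatter, with no clear direction. For compound 3 the estimated value in this assay is 7000 nM, between 2500 nM and 20000 nM. The step from compound 1 to compound 3 is thus expected to be a 1.2-fold lower number from compound 1 to compound 3 (0.07 log units; within the scatter).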

Compound 3, half-maximal inhibitory concentration: 27600 nM
Compound 3: middle estimate off by 3.9-fold (0.60 log units), on the low side; measured number above the stated range.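

In this assay, the pendant aryl position responds to this exchange: 4-methoxyphenyl to 4-chlorophenyl gives a 3.3-fold higher number from compound 1 to compound 3 (0.52 log units; beyond the scatter), so of these two groups methoxy gives the lower number. Both ends of the step are numbers, so it is not capped by the limit held by compound 2: the limit of > 40000 nM in this assay, at which 1 of the 3 values shown sits.

With only two groups shown at this position, the step cannot be assigned to losing methoxy or to gaining chloro. On these data alone, whether a hydroxyl, an amine or an unsubstituted phenyl here would improve on methoxy remains open.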